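The source may report more compounds than this note shows. Statements on the series, on what has been measured and on what is new or still open speak of the compounds shown alone.

Measured in a physicochemical assay for pharmacokinetics, read by HPLC, at pH 7.5, tested at 250 uM; on this read-out lower numbers stand for a shorter-lived compound and higher numbers for a longer-lived compound:
- compound 1 `CN(C)CC1Cc2ccccc2C1=O`: 0.167 h
- compound 2 `CN(C)CC1Cc2c(cccc2C(F)(F)F)C1=O`: 28.9 h
- compound 3 `Cc1ccc2c(c1)CC(CN(C)C)C2=O`: 0.4 h

Compound 1 gives the lowest number of the three. Compound 4 `Cc1ccc2c(c1)C(=O)C(CN(C)C)C2` differs from it by methyl in place of hydrogen on an aromatic carbon, meta to a fused ring and para to a fused ring. The closest guide is a 2.4-fold higher number from compound 1 to compound 3 (0.38 log units; beyond the scatter), which shows the same group on a different aromatic carbon. The step of a 170-fold higher number from compound 1 to compound 2 (2.24 log units; beyond the scatter) brings trifluoromethyl, another group, and so says less here. A small upward step in this assay is therefore expected, possibly none beyond the scatter. The expected change is a 1.7-fold higher number from compound 1 to compound 4 (0.22 log units; within the scatter). For compound 4 the estimated value is 0.28 h, with an expected range from 0.15 h to 0.6 h.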

Compound 4, half-life: 0.233 h
For compound 4 the middle estimate is 1.2-fold (0.08 log units) above the measured one; measured number inside the range.
By their numbers in this assay, from the lowest: compounds 1, 4 and 3 (each within the scatter of the next, the first and the last beyond it); then compound 2.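

In this assay, methyl in place of hydrogen on an aromatic carbon, meta to a fused ring and para to a fused ring, gives a 1.4-fold higher number from compound 1 to compound 4 (0.14 log units; within the scatter) so at this position the change cannot be told apart from no change. Compound 3 and compound 4 carry the same methyl on different aromatic carbons and lie within the scatter of each other, so these numbers do not separate the two positions. No measurement here offers an explanation for this result.

As far as these compounds go, whether trifluoromethyl at this position would bring a step as large as a 170-fold higher number from compound 1 to compound 2 (2.24 log units; beyond the scatter) stays open. From the compounds shown here alone, what a methoxy group or a chlorine atom would do here is also open.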